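Acyl chain length and cytotoxicity in one series

This account rests on a few compounds, and the source may have more. Where it says the series, first, only, none or still open, it means among the compounds named here.

Measured in a functional assay on A549 cells (Homo sapiens) for cytotoxicity, read by sulforhodamine B assay, with a stated time of 72 h; on this read-out higher numbers stand for weaker inhibition and lower numbers for stronger inhibition:
compound 1 `CC(=O)Nc1ccn([C@@H]2CO[C@H](CO)O2)c(=O)n1` gives 6870 nM
compound 2 `CCCC(=O)Nc1ccn([C@@H]2CO[C@H](CO)O2)c(=O)n1` gives 6600 nM
compound 3 `CCCCCCCCC(=O)Nc1ccn([C@@H]2CO[C@H](CO)O2)c(=O)n1` gives 46 nM

Compound 3 stands lowest of the three numbers, with a 140-fold lower number from compound 2 to compound 3 (2.16 log units; beyond the scatter) and a 150-fold lower number from compound 1 to compound 3 (2.17 log units; beyond the scatter) both large and beyond the scatter. Compound 4 `CCCCCCCCCC(=O)Nc1ccn([C@@H]2CO[C@H](CO)O2)c(=O)n1` differs from compound 3 by methyl in place of hydrogen on a saturated chain carbon, eight bonds along the chain from a carbonyl carbon. For the measured compounds named here, the steps that bear on this are the chain extensions already seen: a 1.0-fold lower number from compound 1 to compound 2 (0.02 log units; within the scatter) stayed within the scatter, whereas a 150-fold lower number from compound 1 to compound 3 (2.17 log units; beyond the scatter) and a 140-fold lower number from compound 2 to compound 3 (2.16 log units; beyond the scatter) were large. One further methyl on an already long chain is a smaller change than either of those, so only a modest further lowering in this assay, or none beyond the scatter, is expected, a 1.3-fold lower number from compound 3 to compound 4 (0.12 log units; within the scatter). Compound 4 is therefore estimated at 35 nM, with a range from 10 nM to 120 nM.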

Compound 4, half-maximal inhibitory concentration: 24 nM
Compound 4: the middle estimate sits 1.5-fold (0.16 log units) above what was measured; measured number inside the range.
By their numbers in this assay, from the lowest: compounds 4 and 3 (each within the scatter of the next); then compounds 2 and 1 (each within the scatter of the next).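

In this assay, methyl on a saturated chain carbon, eight bonds along the chain from a carbonyl carbon, gives a 1.9-fold lower number from compound 3 to compound 4 (0.28 log units; within the scatter), so at this length one more carbon does not separate compound 4 from compound 3. The large drop seen with compound 3 persists in compound 4, with a 280-fold lower number from compound 2 to compound 4 (2.44 log units; beyond the scatter) and a 290-fold lower number from compound 1 to compound 4 (2.46 log units; beyond the scatter). No measured evidence on the series accounts for these numbers.

On these data alone, whether a longer chain stays at this level remains open. So does whether an amine or a carboxylic acid at the chain end would be tolerated.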